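Cyclohexyl carbonyl variant of the bis-amide series

This account rests on a few compounds, and the source may have more. Where it says the series, first, only, none or still open, it means among the compounds named here.

Compound 3 `COc1ccccc1C(=O)Nc1cccc(NC(=O)c2ccco2)c1` sits at the edge of an in vitro functional assay on HEK293-A cells for antagonist activity at metabotropic glutamate receptor 5 (Rattus norvegicus), read by calcium flux; on this read-out lower numbers stand for stronger inhibition and higher numbers for weaker inhibition. In this assay compound 3 gives > 30000 nM, which is a limit and not a number. Compound 1 `COc1ccccc1C(=O)Nc1cccc(NC(=O)c2ccc(F)cc2)c1` likewise gives a limit, > 30000 nM. For the measured compounds named here, compound 2 `COc1ccccc1C(=O)Nc1cccc(NC(=O)c2cccc(C#N)c2)c1` gives 1800 nM, the only number among the three; two of the three values rest at the limit of > 30000 nM in this assay, at which 2 of the 3 values shown sit. The step of an at least 16-fold higher number from compound 2 to compound 3 (1.22 log units; beyond the scatter) is large, while a step that the two limits leave unreadable from compound 1 to compound 3 cannot be sized. Compound 4 `COc1ccccc1C(=O)Nc1cccc(NC(=O)C2CCCCC2)c1` differs from compound 3 by cyclohexyl in place of furan-2-yl on a carbonyl carbon. Going by the values given here, no measured step involves a cyclohexyl, and both comparisons from compound 3 begin at a limit. Compound 4 is therefore expected to remain at the limit, with a number no higher from compound 3 to compound 4 (the limit leaves the size open) expected to show no step beyond the scatter. The estimate for compound 4 is 30000 nM, within 10000 nM to 100000 nM.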

Compound 4, half-maximal inhibitory concentration: > 30000 nM
Compound 4: a limit, no number; the forecaster's own chance of this, stated with the estimate: 70%; the middle value lies on the limit itself.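

A saturated carbon ring on this carbonyl carbon fares no better than furan-2-yl or 4-fluorophenyl, and 3-cyanophenyl remains the only group shown here that gives a number, with an at least 16-fold higher number from compound 2 to compound 4 (1.22 log units; beyond the scatter). The steps among compound 1, compound 3 and compound 4 each join two limits and cannot be read. The limit now holds most of the set: the limit of > 30000 nM in this assay, at which 3 of the 4 values shown sit.

Open, going by these compounds, is whether the nitrile needs the phenyl ring, which a cyanocyclohexyl on this carbonyl carbon would test. Also open, on these data alone, is whether an amine or a carboxylic acid in place of the nitrile gives a number.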